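Benzyl variation in the amide series: fluoro for chloro

This account rests on a few compounds, and the source may have more. Where it says the series, first, only, none or still open, it means among the compounds named here.

Series notes. The shared core carries a ring-amine substituent that varies across compound 1 `COc1cc(N)c(Cl)cc1NC(=O)C1CCN(Cc2ccccc2Cl)CC1`, compound 2 `COc1cc(N)c(Cl)cc1NC(=O)C1CCN(CC2CCC2)CC1` and compound 3 `CCC(CC)CN1CCC(C(=O)Nc2cc(Cl)c(N)cc2OC)CC1`. In a functional assay on the whole organism for antagonist activity, with Mus musculus as the target (a lower number here means that less compound is needed, a higher number that more compound is needed for the effect), compound 1 gives only a limit, > 4 mg/kg. Compound 2 likewise gives only a limit in this assay, > 10 mg/kg. Compound 3 too gives only a limit in this assay, > 10 mg/kg. The steps a step that the two limits leave unreadable from compound 1 to compound 2 and a step that the two limits leave unreadable from compound 1 to compound 3 cannot be sized, nor can a step that the two limits leave unreadable from compound 2 to compound 3; the evidence is the limit of > 10 mg/kg in this assay, at which 2 of the 3 values shown sit, and (the limit of > 4 mg/kg in this assay, at which 1 of the 3 values shown sits), so compound 1 stands only as a limit, not as a number.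

Compound 4 `COc1cc(N)c(Cl)cc1NC(=O)C1CCN(Cc2ccc(F)cc2)CC1` differs from compound 1 by 4-fluorophenyl in place of 2-chlorophenyl on a saturated chain carbon bound to an amine nitrogen in a ring. Within the data shown here, no measured step reaches a number, so none gives a size for this change; the expected step that the limit leaves unreadable from compound 1 to compound 4 is therefore set at no readable change. The estimate for compound 4 in this assay is 10 mg/kg, with a range from 3 mg/kg to 40 mg/kg, and a limit rather than a number is again expected as the more likely outcome.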

Compound 4, dose for half-maximal effect: 0.6 mg/kg
Estimate against measurement, compound 4: 17-fold (1.22 log units) above; the measured number lies below the stated range.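

Among the compounds shown, only compound 4 gives a number in this assay, so the group on a saturated chain carbon bound to an amine nitrogen in a ring now has a readable effect on the dose needed. With 4-fluorophenyl in place of 2-chlorophenyl, the change is an at least 6.6-fold lower number from compound 1 to compound 4 (0.82 log units; beyond the scatter), while replacing pentan-3-yl gives an at least 16-fold lower number from compound 3 to compound 4 (1.22 log units; beyond the scatter) and replacing cyclobutyl gives an at least 16-fold lower number from compound 2 to compound 4 (1.22 log units; beyond the scatter). Among these compounds, all three steps start from limits, so each gives only a minimum size, and 4-fluorophenyl is the only group here tied to a number.

The compounds shown do not separate the change of halogen from the change of its place on the phenyl ring; 4-chlorophenyl and 2-fluorophenyl would do so. As far as these compounds go, whether an unsubstituted phenyl or 4-methoxyphenyl group also gives a number in this assay remains open.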